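The compounds below may be only part of what the source reports. "The series", "measured", "known", "first", "only" and "open" are said of these compounds alone.

Two closely related compounds have been measured. Compound 1 `ClCc1ccccc1Cn1cnc2c(Cl)ncnc21` in a functional assay on MDA-MB-231 cells (Homo sapiens) for cytotoxicity, read by sulforhodamine B assay, with a stated time of 48 h (on this read-out higher numbers stand for weaker inhibition of growth and lower numbers for stronger inhibition of growth), gives 3020 nM. Compound 2 `ClCc1cccc(Cn2cnc3ncnc(Cl)c32)c1` differs from it only in where its substituent sits, and in this assay compound 2 gives 1730 nM. Among the compounds with values here, compound 2 therefore stands nearest compound 1, the only other number available, and the gap between them falls within the scatter of this kind of measurement, so the two cannot be told apart on these figures.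

Compound 3 `ClCc1cccc(Cn2cnc3nc(Cl)nc(Cl)c32)c1` differs from compound 2 in one place: chloro in place of hydrogen on an aromatic carbon. Within the data shown here, no measured pair shows what this change does on the shared core, so no step is known from the data. In the absence of such a pair, and with both measured compounds sitting close together, a step that stays within the scatter is expected, in no clear direction; the step of a 1.2-fold lower number from compound 2 to compound 3 (0.06 log units; within the scatter) is the estimate that expresses this. Compound 3 is accordingly expected to give about 1500 nM in this assay, with a range from 500 nM to 5000 nM.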

Compound 3, concentration for 50% growth inhibition: 460 nM
Compound 3: the middle estimate sits 3.3-fold (0.51 log units) above what was measured, outside the stated range (below it).
By their numbers in this assay, from the lowest: compound 3; then compounds 2 and 1 (each within the scatter of the next).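

In this assay, chloro in place of hydrogen on the aromatic carbon between two ring nitrogen atoms comes with a 3.8-fold lower number from compound 2 to compound 3 (0.58 log units; beyond the scatter), so this position of the shared core can register a change of a single heavy atom. Within the data shown here, compound 1 and compound 2, which differ only in where their substituent sits, could not be told apart, whereas this step is the first to lie beyond the scatter and shows stronger inhibition of growth for compound 3 than for compound 2. Nothing available bears on why the number falls at this position, and this single pair gives no account of the step.

Whether the lower number belongs to chloro in particular remains open, since other groups on this aromatic carbon, such as an amine, a methoxy group or a methyl group, do not appear among the compounds shown. Also open, as far as these compounds go, is whether chloro at this carbon would bring a step of similar size with the substituent placed as in compound 1, or on any other core.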